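Allyloxy in place of fluoro on the shared core

The source may hold more compounds than are shown below. What is called first, only, known or untested is meant among the compounds shown, and "the series" means these compounds.

Of the compounds shown here, three on one shared core have been measured in a physicochemical assay for lipophilicity, measured as octanol-water partition; a lower number here means a more polar compound, a higher number a more lipophilic compound. Compound 1 `CCO/N=C/Nc1cc(Cl)c(F)c(Cl)c1` gives 4, the highest of the three numbers. Compound 2 `CCO/N=C/Nc1cc(Cl)c(O)c(Cl)c1` gives 2.8, and compound 3 `CCO/N=C/Nc1cc(Cl)c(OC)c(Cl)c1` gives 3.7. The step from compound 1 to compound 2 was a number 1.20 log units lower from compound 1 to compound 2 (beyond the scatter), the step from compound 1 to compound 3 was a number 0.30 log units lower from compound 1 to compound 3 (within the scatter), and the step from compound 2 to compound 3 was a number 0.90 log units higher from compound 2 to compound 3 (beyond the scatter).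

The unmeasured compound 4 `C=CCOc1c(Cl)cc(N/C=N/OCC)cc1Cl` differs from compound 1 in one place: allyloxy in place of fluoro on an aromatic carbon. Within the data shown here, the step that bears most directly on it is the one from compound 1 to compound 3, which stayed within the scatter; compound 4 carries an allyloxy group of 4 heavy atoms rather than a methoxy group, so a larger rise than that of a number 0.30 log units lower from compound 1 to compound 3 (within the scatter) is expected in this assay. The expected step is a number 0.70 log units higher from compound 1 to compound 4 (beyond the scatter). Compound 4 is therefore estimated at 4.7, between 4.2 and 5.2.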

Compound 4, partition coefficient: 4.3
Estimate against measurement, compound 4: 0.40 log units above; measured number inside the range.
By their numbers in this assay, from the lowest: compound 2; then compounds 3, 1 and 4 (each within the scatter of the next, the first and the last beyond it).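

In this assay, allyloxy with its 4 heavy atoms can stand in place of fluoro on this aromatic carbon without leaving the scatter, as a number 0.30 log units higher from compound 1 to compound 4 (within the scatter) shows, so neither ether at this position is separated from compound 1. The two ethers are separated from each other, however, with a number 0.60 log units higher from compound 3 to compound 4 (beyond the scatter), and on the oxygen of compound 2 the allyl group gives a number 1.50 log units higher from compound 2 to compound 4 (beyond the scatter), a larger step than the one seen with methyl. No measurement shown gives a reason for these steps.

The compounds shown leave open how a saturated propoxy group would compare with allyloxy, and so whether the double bond has any part in these steps. Going by these compounds, how an amine or a carboxylic acid would read at this position also remains open.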